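The source may report more compounds than this note shows. Statements on the series, on what has been measured and on what is new or still open speak of the compounds shown alone.

Measured compounds:
compound 1, `COc1ccc(/C=N\NC(=S)NC(C)(C)CCC[C@](C)(O)[C@@H]2CC=C(C)CC2)cc1`: 6730 nM
compound 2, `CC1=CC[C@@H]([C@@](C)(O)CCCC(C)(C)NC(=S)N/N=C\c2ccccc2Cl)CC1`: a limit only, > 100000 nM

In a functional assay on NCI/ADR cells (Homo sapiens) for cytotoxicity, read by sulforhodamine B assay (on this read-out higher numbers stand for weaker inhibition of growth and lower numbers for stronger inhibition of growth), compound 1 gives 6730 nM. For compound 2 this assay reports no number but only a limit, > 100000 nM, so compound 2 sits at the weak end of what has been measured here (the limit of > 100000 nM in this assay, at which 1 of the 2 values shown sits). Going by the values given here, the one measured step, an at least 14-fold higher number from compound 1 to compound 2 (1.17 log units; beyond the scatter), shows that the group on the carbon double-bonded to nitrogen can move the number a long way. Compound 3, `CC1=CC[C@@H]([C@@](C)(O)CCCC(C)(C)NC(=S)N/N=C(/C)c2ccccc2)CC1`, is not yet measured; it differs from compound 2 by a group of 9 heavy atoms (8 carbon, 1 nitrogen; one six-membered aromatic ring of carbon only) in place of a group of 9 heavy atoms (7 carbon, 1 nitrogen, 1 chlorine; one six-membered aromatic ring of carbon only), on an amide-type nitrogen. That step takes away the chlorine-bearing group and brings in a group with one more carbon, so the measured step bears on it only loosely. Compound 3 is therefore expected to fall below the limit of compound 2, by about an at least 2.5-fold lower number from compound 2 to compound 3 (0.39 log units; beyond the scatter), with wide uncertainty. The estimate for compound 3 in this assay is 40000 nM, between 8000 nM and 150000 nM.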

Compound 3, concentration for 50% growth inhibition: 750 nM
Compound 3: middle estimate off by 53-fold (1.73 log units), on the high side; measured number outside the range, below it.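

This position can do more than weaken growth inhibition: the group with 8 carbon and 1 nitrogen, on the amide-type nitrogen, brings a 9.0-fold lower number from compound 1 to compound 3 (0.95 log units; beyond the scatter) in this assay, which makes compound 3 the strongest of the three. Against the chlorine-bearing group the gap is wider still, an at least 130-fold lower number from compound 2 to compound 3 (2.12 log units; beyond the scatter), so the groups at this one place span a very wide range. That gap has only one firm end, since compound 2 gives no number, only a limit: the limit of > 100000 nM in this assay, at which 1 of the 3 values shown sits.

The compounds shown leave open whether the extra carbon or the ring without chlorine or methoxy carries the gain. They also leave open how an amine or a carboxylic acid on that ring would read in this assay.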